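The source may hold more compounds than are shown below. What is called first, only, known or untested is meant among the compounds shown, and "the series" means these compounds.

Measured so far in a functional assay on A-375 cells (Homo sapiens) for antiproliferative activity, read by MTT assay, with a stated time of 48 h; a lower number here means a stronger inhibitor, a higher number a weaker inhibitor: compound 1 `CCCCCCCc1nc(N)n(CC(=O)Nc2ccccc2)c1-c1ccccc1Br`, 9200 nM; compound 2 `Nc1nc(Cc2ccccc2)c(-c2ccccc2Br)n1CC(=O)Nc1ccccc1`, 5200 nM; compound 3 `COc1ccc(Cc2nc(N)n(CC(=O)Nc3ccccc3)c2-c2ccccc2Br)cc1`, 1400 nM.

Compound 1 gives the highest number of the three; the other two sit below it by a 1.8-fold lower number from compound 1 to compound 2 (0.25 log units; within the scatter) and by a 6.6-fold lower number from compound 1 to compound 3 (0.82 log units; beyond the scatter). Compound 4 `CCCCCCCc1nc(N)n(CC(=O)Nc2ccc(C)cc2)c1-c1ccccc1Br` differs from compound 1 only at the phenyl of the phenylcarbamoyl group: methyl in place of hydrogen on an aromatic carbon. Within the data shown here, no measured step touches that group; all three alter the chain on the far side of the shared core. The nearest comparison, a 3.7-fold lower number from compound 2 to compound 3 (0.57 log units; beyond the scatter), also adds a small group to an aromatic carbon, but on the other ring, so it carries little weight here. Nothing beyond the scatter is therefore expected for compound 4, the step being estimated as a 1.3-fold lower number from compound 1 to compound 4 (0.12 log units; within the scatter). Compound 4 is thus estimated at 7000 nM in this assay, with a range of 3000 nM to 20000 nM.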

Compound 4, half-maximal inhibitory concentration: 5200 nM
Compound 4: middle estimate off by 1.3-fold (0.13 log units), on the high side, and the stated range covers the measured number.
By their numbers in this assay, from the lowest: compound 3; then compounds 2, 4 and 1 (each within the scatter of the next).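

First reading at the phenyl of the phenylcarbamoyl group: in this assay, methyl on this aromatic carbon, para to a large group, gives a 1.8-fold lower number from compound 1 to compound 4 (0.25 log units; within the scatter). Among these compounds, with the hexyl chain in place, this site therefore accepts a methyl without a shift beyond the scatter, so the only changes beyond the scatter so far remain those on the far side of the shared core. No measurement on hand offers an explanation for this step.

Still open, going by these compounds, is whether a carboxylic acid, an amine or a chlorine at this site would shift the number beyond the scatter. Also open, on these data alone, is whether the methyl reads the same when the 4-methoxyphenyl of compound 3 replaces hexyl.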